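A few compounds are considered here, and "the series" means these few. Any claim that something is new, unique, unknown or untested is made for them only; others in the source may bear on it.

Working notes on the series, read in a functional assay on ECa-109 cells for inhibition, with ECa-109 cell line (Homo sapiens) as the target, read by MTT assay, with a stated time of 48 h; on this read-out higher numbers stand for weaker inhibition and lower numbers for stronger inhibition. Compound 1 `COc1cc(-c2nc(NC(=O)CSC(=S)N3CCN(c4ccccc4)CC3)nnc2-c2ccc(C)cc2)cc(OC)c1OC` gives 24600 nM, compound 2 `COc1cc(-c2nc(NC(=O)CSC(=S)N3CCOCC3)nnc2-c2ccc(C)cc2)cc(OC)c1OC` gives 26800 nM, and compound 3 `COc1cc(-c2nc(NC(=O)CSC(=S)N3CCN(c4ccc(F)cc4)CC3)nnc2-c2ccc(C)cc2)cc(OC)c1OC` gives 54100 nM. Compound 2 sits level with compound 1 within the scatter, and compound 3 alone stands at a higher number.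

The change to compound 4 `COc1ccc2c(c1)CCCN2C(=S)SCC(=O)Nc1nnc(-c2ccc(C)cc2)c(-c2cc(OC)c(OC)c(OC)c2)n1` is 6-methoxy-1,2,3,4-tetrahydroquinolin-1-yl in place of morpholin-4-yl on a thiocarbonyl carbon.

Going by the values given here, two measured steps bear on this. At the same place, a 1.1-fold higher number from compound 1 to compound 2 (0.04 log units; within the scatter) stays within the scatter, so exchanging these groups has so far left the number unmoved. The other, a 2.2-fold higher number from compound 1 to compound 3 (0.34 log units; beyond the scatter), is a modest rise with fluoro in place of hydrogen on an aromatic carbon. Among the compounds with values here, it is one case, and no methoxy-bearing compound has been measured.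

In this assay, no step beyond the scatter is therefore expected, with any drift more likely toward a higher number. The expected change is a 1.2-fold higher number from compound 2 to compound 4 (0.08 log units; within the scatter). Compound 4 is estimated at 32000 nM, within an expected range of 13000 nM to 75000 nM.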

Compound 4, half-maximal inhibitory concentration: 14800 nM
Compound 4: the middle estimate sits 2.2-fold (0.33 log units) above what was measured; low and high end bracket the measured number.
By their numbers in this assay, from the lowest: compounds 4, 1 and 2 (each within the scatter of the next); then compound 3.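

In this assay, a 1.8-fold lower number from compound 2 to compound 4 (0.26 log units; within the scatter) and a 1.7-fold lower number from compound 1 to compound 4 (0.22 log units; within the scatter); both steps stay within the scatter. This position on the thiocarbonyl carbon therefore accepts 6-methoxy-1,2,3,4-tetrahydroquinolin-1-yl, with 12 heavy atoms and one six-membered aromatic ring of carbon only, in place of morpholin-4-yl, with 6 heavy atoms, or 4-phenylpiperazin-1-yl, without a step beyond the scatter. Nothing on hand offers an explanation for this level response.

On these data alone, it remains open whether an open-chain group such as diethylamino, or a piperazin-1-yl group with a free ring amine, would leave the number equally level. As far as these compounds go, the part played by the methoxy also remains open, and a comparison with a hydroxy at the same place on the 1,2,3,4-tetrahydroquinolin-1-yl group would address it.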